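The compounds below may be only part of what the source reports. "The series", "measured", "known", "first", "only" and "open" are said of these compounds alone.

Within the data shown here, in a functional assay on DU-145 cells (Homo sapiens) for inhibition, read by trypan blue exclusion, with a stated time of 96 h (on this read-out lower numbers stand for stronger inhibition of growth and higher numbers for weaker inhibition of growth), compound 1 `O=C(O)c1ccc(C(=O)/C(=C\c2ccc(Br)c([N+](=O)[O-])c2)SCc2ccccc2Cl)cc1` gives 1000 nM, the lowest of the three numbers measured so far. Compound 2 `COc1ccccc1/C=C(/SCc1ccc(Cl)cc1)C(=O)c1ccc([N+](=O)[O-])cc1` gives 10000 nM and compound 3 `COc1ccc(S(=O)(=O)/C(=C/c2ccc(C)s2)C(=O)c2ccc(Cl)cc2)cc1` gives 25000 nM, and both lie beyond the scatter from compound 1. Compound 4 `O=C(O)c1ccc(C(=O)/C(=C\c2ccc(Br)c([N+](=O)[O-])c2)SCc2ccc(Cl)cc2)cc1` is still unmeasured. It differs from compound 1 by 4-chlorophenyl in place of 2-chlorophenyl on a saturated chain carbon bound to a sulfur, with 4-chlorophenyl in place of 2-chlorophenyl on a saturated chain carbon bound to a sulfur. Among the measured compounds shown here, no measured pair isolates this change, so the data offer no direct guide to its size. No shift beyond the scatter is expected, and the estimated result is no change at the digits printed from compound 1 to compound 4 (within the scatter). For compound 4 the expected value is 1000 nM, with an estimated range of 300 nM to 3500 nM.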

Compound 4, concentration for 50% growth inhibition: < 1000 nM
Compound 4: no number, only a limit; the forecaster's own chance of this, stated with the estimate: 3%; the middle value sits exactly at the limit.
By their numbers in this assay, from the lowest: compound 1; then compound 2; then compound 3.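

In this assay, putting 4-chlorophenyl in place of 2-chlorophenyl on a saturated chain carbon bound to a sulfur gives a number no higher from compound 1 to compound 4 (the limit leaves the size open). Among these compounds, this is the first step that isolates a single place, and it shows that this change does not raise the number, something the earlier compounds could not show. Compound 4 stands as a limit and not as a number: the limit of < 1000 nM in this assay, at which 1 of the 4 values shown sits.

The size of the step therefore stays unread. On these data alone, whether an unsubstituted phenyl, an amine or a longer chain would hold the number at this place also remains open.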